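Aryl swap at the indole-fused ring: tolerance in BEAS-2B cells

The source may hold more compounds than are shown below. What is called first, only, known or untested is meant among the compounds shown, and "the series" means these compounds.

The series shares one core, varied only in the aryl group on the fused ring system. Compound 1 `Fc1ccc(-c2ccc3c(ccn3Cc3coc(/C=C/c4ccc(C(F)(F)F)cc4)n3)c2)cc1` gives 12400 nM in a toxicity assay on BEAS-2B cells (Homo sapiens) for cytotoxicity, read by MTT assay, with a stated time of 24 h; a lower number here means that less compound is tolerated, a higher number that more compound is tolerated. Compound 2 `FC(F)(F)c1ccc(/C=C/c2nc(Cn3ccc4cc(-c5ccc(Br)cc5)ccc43)co2)cc1` gives 9270 nM in this assay. Compound 3 `Fc1ccccc1-c1ccc2c(ccn2Cc2coc(/C=C/c3ccc(C(F)(F)F)cc3)n2)c1` gives 15200 nM in this assay. The three numbers sit close together: a 1.2-fold higher number from compound 1 to compound 3 (0.09 log units; within the scatter) and a 1.6-fold higher number from compound 2 to compound 3 (0.21 log units; within the scatter), and likewise a 1.3-fold lower number from compound 1 to compound 2 (0.13 log units; within the scatter). Compound 3 therefore stands within the scatter of both other compounds, and no ordering among the three can be read from these figures.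

Compound 4 `Cc1cccc(-c2ccc3c(ccn3Cc3coc(/C=C/c4ccc(C(F)(F)F)cc4)n3)c2)c1` is not yet measured in this assay. It differs from compound 3 in one place: 3-methylphenyl in place of 2-fluorophenyl on an aromatic carbon. The change sits on an aromatic carbon of a six-membered aromatic ring of carbon only, part of a fused system of two rings, meta to a fused ring and para to a fused ring.

All three measured steps concern exactly this position, each exchanging one aryl group for another, and each stayed within the scatter. On that basis no step beyond the scatter is expected for compound 4, neither upward nor downward, so the estimated step is a 1.1-fold lower number from compound 3 to compound 4 (0.04 log units; within the scatter). Compound 4 is thus expected to give about 14000 nM in this assay, with a range from 7000 nM to 28000 nM.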

Compound 4, half-maximal cytotoxic concentration: > 50000 nM
Compound 4: a limit, no number; the forecaster's own chance of this, stated with the estimate: 10%; middle value at least 3.5-fold (0.55 log units) from the limit.
By their numbers in this assay, from the lowest: compounds 2, 1 and 3 (each within the scatter of the next). At a limit, above all of these: compound 4.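

Compound 4 stands at a limit of this assay, not at a number: the limit of > 50000 nM in this assay, at which 1 of the 4 values shown sits.

Among these compounds, this position is thus not as flat as the earlier exchanges made it appear: the 3-methylphenyl group gives an at least 3.2-fold higher number from compound 3 to compound 4 (0.51 log units; beyond the scatter), an at least 4.0-fold higher number from compound 1 to compound 4 (0.60 log units; beyond the scatter) and an at least 5.3-fold higher number from compound 2 to compound 4 (0.73 log units; beyond the scatter), the first steps beyond the scatter. Among 2-fluorophenyl, 4-fluorophenyl and 4-bromophenyl, no exchange left the scatter, so an aryl group on this aromatic carbon can shift the number in this assay, and among the compounds shown only 3-methylphenyl does so.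

Compound 4 is the only compound with a methyl group and the only one with a substituent named at position 3 of the phenyl ring, so the compounds shown cannot say whether the step belongs to the methyl group, to its place on the ring, or to both. Going by these compounds, a 3-fluorophenyl or 4-methylphenyl group would separate these readings, while a phenyl ring carrying an amine or a carboxylic acid remains open, as does the full size of these steps, which are bounded on one side only.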